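This account rests on a few compounds, and the source may have more. Where it says the series, first, only, none or still open, it means among the compounds named here.

Measured in a functional assay on cells (Homo sapiens) for antiproliferative activity, read by MTT assay, with a stated time of 48 h; a higher number here means a weaker inhibitor, a lower number a stronger inhibitor:
- compound 1 `Cn1c(N)c(-c2nc3ccccc3[nH]2)c2nc(C#N)c(C#N)nc21`: > 50000 nM (a limit)
- compound 2 `N#Cc1nc2c(-c3nc4ccccc4[nH]3)c(N)n(CCO)c2nc1C#N`: > 50000 nM (a limit)
- compound 3 `CN(C)CCCn1c(N)c(-c2nc3ccccc3[nH]2)c2nc(C#N)c(C#N)nc21`: 1820 nM

Compound 3, at 1820 nM, is the only one of the three with a real number. Compounds 1 and 2 stand only at a limit, (the limit of > 50000 nM in this assay, at which 2 of the 3 values shown sit).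

Compound 4 `CCN(CC)CCCCn1c(N)c(-c2nc3ccccc3[nH]2)c2nc(C#N)c(C#N)nc21` differs from compound 3 by (diethylamino)methyl in place of dimethylamino on a saturated chain carbon, three bonds along the chain from an aromatic nitrogen. This puts (diethylamino)methyl in place of dimethylamino on a saturated chain carbon, three bonds along the chain from an aromatic nitrogen. Read one bond further out, 3-(dimethylamino)propyl becomes 4-(diethylamino)butyl.

Among the compounds with values here, two measured steps bear on this, and both are large: an at least 27-fold lower number from compound 1 to compound 3 (1.43 log units; beyond the scatter), and an at least 27-fold lower number from compound 2 to compound 3 (1.43 log units; beyond the scatter). Both bring in the amino chain, which compound 4 keeps in longer form, but neither varies that chain's length or the groups on its nitrogen. No step beyond the scatter is therefore expected in this assay, and no firm direction. The expected step is a 1.2-fold lower number from compound 3 to compound 4 (0.08 log units; within the scatter). Compound 4 is estimated at 1500 nM, with an expected range of 500 nM to 6000 nM.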

Compound 4, half-maximal inhibitory concentration: 640 nM
Compound 4: middle estimate off by 2.3-fold (0.37 log units), on the high side; the range from low to high includes it.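

In this assay, within the data shown here, the earlier compounds showed only that bringing in the amino chain goes with a large step, whereas this change shows that the chain itself still has an effect: 3-(dimethylamino)propyl giving way to 4-(diethylamino)butyl brings a 2.8-fold lower number from compound 3 to compound 4 (0.45 log units; beyond the scatter) on a core that already carries an amino chain. Against the compounds without an amino chain the distance widens, with an at least 78-fold lower number from compound 2 to compound 4 (1.89 log units; beyond the scatter) and with an at least 78-fold lower number from compound 1 to compound 4 (1.89 log units; beyond the scatter) as the two large steps. Those two steps are bounded on one side, since compound 1 and compound 2 stand only at a limit: the limit of > 50000 nM in this assay, at which 2 of the 4 values shown sit.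

The lengthening of the chain and the change from methyl to ethyl on its nitrogen arrive together, so the compounds shown do not tell which of them carries the step. Open too, as far as these compounds go, is how 4-(dimethylamino)butyl, 3-(diethylamino)propyl or a piperidine at the chain end would read here.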